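A few compounds are considered here, and "the series" means these few. Any claim that something is new, unique, unknown or untested is made for them only; others in the source may bear on it.

Three measured compounds of this series share one core and differ only in the group on the saturated chain carbon bound to the carbonyl carbon. Compound 1 `CC(C)(O)C(CCC/C=C(\c1ccccc1)c1cccnc1)C(=O)O` gives 42 nM in an assay (Equus caballus) for inhibition of Thromboxane-A synthase (Homo sapiens), using microsomes; on this read-out lower numbers stand for stronger inhibition and higher numbers for weaker inhibition. Compound 2 `O=C(O)C(CCC/C=C(\c1ccccc1)c1cccnc1)C1=CCCC1` gives 60 nM in this assay, and compound 3 `COCC(CCC/C=C(\c1ccccc1)c1cccnc1)C(=O)O` gives 41 nM in this assay. The steps among them are small: a 1.4-fold higher number from compound 1 to compound 2 (0.15 log units; within the scatter), a 1.0-fold lower number from compound 1 to compound 3 (0.01 log units; within the scatter) and a 1.5-fold lower number from compound 2 to compound 3 (0.17 log units; within the scatter). Compound 3 carries the lowest of the three numbers, but its distance to compound 1 and to compound 2 stays within the scatter, so no order among the three can be read.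

Compound 4 `C=CCC(CCC/C=C(\c1ccccc1)c1cccnc1)C(=O)O` is not yet measured. It differs from compound 3 by vinyl in place of methoxy on a saturated chain carbon, two bonds along the chain from a carbonyl carbon. Among the compounds with values here, the three measured steps each replace a group on the saturated chain carbon bound to the carbonyl carbon, and none moved the number beyond the scatter; they are the only evidence bearing on this change. On that basis a step within the scatter, without a clear direction, is expected in this assay: a 1.1-fold higher number from compound 3 to compound 4 (0.04 log units; within the scatter). Compound 4 is therefore expected to give about 45 nM in this assay, with a range from 20 nM to 110 nM.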

Compound 4, half-maximal inhibitory concentration: 50 nM
Compound 4: the middle estimate sits 1.1-fold (0.05 log units) below what was measured; the range from low to high includes it.
By their numbers in this assay, from the lowest: compounds 3, 1, 4 and 2 (each within the scatter of the next).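

In this assay the allyl group joins the others at this carbon without separating from them: a 1.2-fold higher number from compound 3 to compound 4 (0.09 log units; within the scatter), a 1.2-fold higher number from compound 1 to compound 4 (0.08 log units; within the scatter) and a 1.2-fold lower number from compound 2 to compound 4 (0.08 log units; within the scatter). With vinyl in place of methoxy, the series now holds two groups free of oxygen, allyl and cyclopent-1-en-1-yl, and both stay within the scatter of the oxygen-bearing methoxymethyl and 1-hydroxy-1-methylethyl, so the four groups still give no order. Nothing measured here accounts for this flat picture.

The compounds shown leave open whether an amine, a second carboxylic acid or a longer chain on this carbon would move the number beyond the scatter. They also leave open whether the same flat picture would hold with any change to the shared core.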